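Azido in place of bromo on the shared core

The compounds below may be only part of what the source reports. "The series", "measured", "known", "first", "only" and "open" are said of these compounds alone.

Compound 1 `Cc1nn(C)c2c1C(c1cccc(Br)c1)=NCCN2` carries a bromo group on its six-membered aromatic ring of carbon only. In a functional assay on the whole organism for positive allosteric modulation, with Rattus norvegicus as the target (on this read-out higher numbers stand for an effect only at larger amounts of compound and lower numbers for an effect already at smaller amounts), compound 1 gives 0.63 mg/kg, the lowest of the two numbers measured in this set. Compound 2 `CCc1nn(C)c2c1C(c1cccc(Br)c1)=NCCN2` gives 1.25 mg/kg in this assay, and the step of a 2.0-fold higher number from compound 1 to compound 2 (0.30 log units; within the scatter) stays within the scatter of the measurement. Compound 3 `Cc1ccc(C)c(C2=NCCNc3c2c(C)nn3C)c1` yields only a limit in this assay, > 10 mg/kg.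

Compound 4 `Cc1nn(C)c2c1C(c1cccc(N=[N+]=[N-])c1)=NCCN2` differs from compound 1 in a single place: azido in place of bromo on an aromatic carbon. Among the measured compounds shown here, no measured step in this assay concerns that place or that kind of exchange. For the measured compounds named here, the one step that has been measured, the methyl in place of hydrogen on a saturated chain carbon bound to an aromatic carbon between compound 1 and compound 2, sits elsewhere on the core and did not move the read-out beyond the scatter. Going by the values given here, the swap of bromo for azido therefore has no measured counterpart here, and the expectation for compound 4 rests on compound 1 alone, with a step of a 2.0-fold higher number from compound 1 to compound 4 (0.30 log units; within the scatter) that is expected to remain modest and without a firm direction. Compound 4 is estimated at 1.25 mg/kg in this assay, with a range from 0.4 mg/kg to 5 mg/kg.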

Compound 4, minimum effective dose: 2.5 mg/kg
Estimate against measurement, compound 4: 2.0-fold (0.30 log units) below, and the stated range covers the measured number.
By their numbers in this assay, from the lowest: compounds 1, 2 and 4 (each within the scatter of the next, the first and the last beyond it). At a limit, above all of these: compound 3.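

The exchange of bromo for azido on an aromatic carbon gives a 4.0-fold higher number from compound 1 to compound 4 (0.60 log units; beyond the scatter) in this assay and so supplies the first measured step at this position, and the only step shown that lies beyond the scatter. This place on the six-membered aromatic ring of carbon only is therefore not indifferent to what it carries: with azido in place of bromo, the effect appears only at larger amounts of compound, although the step remains modest. Nothing at hand bears on why this exchange has this result, so the data give its size and direction and no more.

From the compounds shown here alone, with only bromo and azido compared at this place on the shared core, it remains open whether an amine, a nitrile or a methoxy group there would give a number close to that of compound 1 or one closer to that of compound 4. Going by these compounds, it is also open whether the same exchange would give a step of similar size on the longer chain of compound 2.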